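The source may report more compounds than this note shows. Statements on the series, on what has been measured and on what is new or still open speak of the compounds shown alone.

Among the measured compounds shown here, the three compounds measured so far share one core and differ only in the group carried on the outer ring. Compound 1 `CC(C)N(Cc1cccc(OCCCCCC(=O)O)c1)C(=O)c1ccc(-c2cccc(N(C)C)c2)cc1`, compound 2 `CCOc1cccc(-c2ccc(C(=O)N(Cc3cccc(OCCCCCC(=O)O)c3)C(C)C)cc2)c1` and compound 3 `CC(C)N(Cc1cccc(OCCCCCC(=O)O)c1)C(=O)c1ccc(-c2c[nH]c3ccccc23)cc1` were all tested in an ADME assay on BJ cells (Homo sapiens) for cytotoxicity, read by CellTiter-Glo and resazurin assay, with a stated time of 72 h; on this read-out higher numbers stand for an effect only at larger amounts of compound and lower numbers for an effect already at smaller amounts. For compound 1 the assay gives only a limit, > 26000 nM. For compound 2 the assay likewise gives only a limit, > 20800 nM. For compound 3 the reported value is again a limit, > 26000 nM. With every value being a limit, none of the steps between these compounds can be read: a step that the two limits leave unreadable from compound 1 to compound 2, a step that the two limits leave unreadable from compound 1 to compound 3 and a step that the two limits leave unreadable from compound 2 to compound 3. Compound 3 therefore stands together with compound 1 at the limit of > 26000 nM in this assay, at which 2 of the 3 values shown sit, while compound 2 sits at the limit of > 20800 nM in this assay, at which 1 of the 3 values shown sits; all three show no cytotoxic effect within the tested range.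

Compound 4 `CC(C)N(Cc1cccc(OCCCCCC(=O)O)c1)C(=O)c1ccc(-c2cccc(F)c2)cc1` differs from compound 3 by 3-fluorophenyl in place of 1H-indol-3-yl on an aromatic carbon. The steps that touch this same position of the core, from compound 1 and from compound 2 to compound 3, are both unreadable, so they give no size to carry over. No step beyond the scatter is expected in this assay, and the result for compound 4 is expected to be a limit again. Compound 4 is estimated at 30000 nM, within 15000 nM to 80000 nM. This estimate corresponds to an expected step that the limit leaves unreadable from compound 3 to compound 4.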

Compound 4, half-maximal effective concentration: > 26000 nM
Compound 4: no number, only a limit; the forecaster's own chance of this, stated with the estimate: 85%; the middle value does not contradict the limit.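

In this assay compound 4 gives only a limit, > 26000 nM. Among the compounds shown here, with compound 1, compound 2 and compound 3 also resting on limits, no step from any of them to compound 4 can be read. The compounds shown leave open how far these four outer-ring groups truly differ, and whether any group on the shared core brings a cytotoxic effect within the tested range.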